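This account rests on a few compounds, and the source may have more. Where it says the series, first, only, none or still open, it means among the compounds named here.

Measured compounds:
compound 1 `O=[N+]([O-])c1cc2c(OCCC3CCCCN3)c(-c3ccccc3)c(O)nc2cc1Cl` — in a functional assay on cells (Pituitary gland cell) for antagonist activity at Gonadotropin-releasing hormone receptor (Rattus norvegicus) (on this read-out lower numbers stand for stronger inhibition and higher numbers for weaker inhibition), compound 1 gives 410 nM
compound 2 `Cc1cc(-c2c(O)nc3cc(Cl)c([N+](=O)[O-])cc3c2OCCC2CCCCN2)cc(C(C)O)c1` — in this assay compound 2 gives 63 nM
compound 3 `O=[N+]([O-])c1cc2c(OCCC3CCCCN3)c(-c3ccc4ccccc4c3)c(O)nc2cc1Cl` — in this assay compound 3 gives 53 nM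

Compound 2 stands second highest of the three numbers; its nearest neighbour is compound 3, within the scatter, and its furthest is compound 1, a higher number beyond the scatter.

Compound 4 `O=[N+]([O-])c1cc2c(OCCC3CCCCN3)c(-c3cc(Cl)cc(Cl)c3)c(O)nc2cc1Cl` is not yet measured. It differs from compound 2 in one place: 3,5-dichlorophenyl in place of 3-(1-hydroxyethyl)-5-methylphenyl on an aromatic carbon.

Among the compounds with values here, two measured steps bear on this. Both replace the plain phenyl of compound 1 with a substituted aryl: a 6.5-fold lower number from compound 1 to compound 2 (0.81 log units; beyond the scatter) and a 7.7-fold lower number from compound 1 to compound 3 (0.89 log units; beyond the scatter), each a modest lowering. The step between the two substituted aryls, a 1.2-fold lower number from compound 2 to compound 3 (0.08 log units; within the scatter), is within the scatter, so the two aryl substitution patterns seen so far give the same number. Compound 4 carries a third substituted aryl, with no donor or acceptor, so the data give no ground to expect a step beyond the scatter in either direction in this assay; the nearest guide is the level shared by compound 2 and compound 3.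

Compound 4 is therefore expected to give about 80 nM in this assay, with a range from 25 nM to 250 nM. The expected step of a 1.3-fold higher number from compound 2 to compound 4 (0.10 log units; within the scatter) is estimated to stay within the scatter.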

Compound 4, half-maximal inhibitory concentration: 24 nM
Compound 4: the middle estimate sits 3.3-fold (0.52 log units) above what was measured, outside the stated range (below it).
By their numbers in this assay, from the lowest: compound 4; then compounds 3 and 2 (each within the scatter of the next); then compound 1.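

On the aryl position of the shared core, ortho to the 2-(piperidin-2-yl)ethoxy group, substituted aryls are no longer all on one level in this assay: 3,5-dichlorophenyl separates from both earlier ones, with a 2.6-fold lower number from compound 2 to compound 4 (0.42 log units; beyond the scatter) and a 2.2-fold lower number from compound 3 to compound 4 (0.34 log units; beyond the scatter), whereas 3-(1-hydroxyethyl)-5-methylphenyl and naphthalen-2-yl could not be told apart. Within the data shown here, measured against the plain phenyl, the change gives a 17-fold lower number from compound 1 to compound 4 (1.23 log units; beyond the scatter), the only large step, and the entering group has 0 hydrogen-bond donors and 0 hydrogen-bond acceptors, so a hydroxy-bearing side chain on this aryl is not required for the lowest number seen here. No measurement bears on why 3,5-dichlorophenyl gives this step.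

The compounds shown leave open whether the step follows the chlorine atoms themselves or the arrangement of the two substituents, which 3-chlorophenyl, 4-chlorophenyl and 3,5-dimethylphenyl on the same core would separate. Also open is whether the order among these aryls holds with a group other than the 2-(piperidin-2-yl)ethoxy chain, such as a shorter aminoethoxy chain.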